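The compounds below may be only part of what the source reports. "The series", "measured", "known", "first", "only" and "open" are said of these compounds alone.

Of the compounds shown here, two have so far been tested in an ADME assay on CEM-SS cells (Homo sapiens) for cytotoxicity, read by XTT assay, with a stated time of 6 days; a lower number here means that less compound is tolerated, a higher number that more compound is tolerated. Compound 1 `CCCC(=O)OCSc1ccccc1C(=O)NCC(N)=O` gives only a limit of the assay, > 100 uM. For the measured compounds named here, compound 2 `CCCC(=O)OCSc1ccccc1C(=O)NCCCCC(N)=O` gives the only proper number, 51.7 uM. Going by the values given here, the single measured step is an at least 1.9-fold lower number from compound 1 to compound 2 (0.28 log units; that floor lies within the scatter); it rests on (the limit of > 100 uM in this assay, at which 1 of the 2 values shown sits), so its true size is open. Compound 3 `CCCC(=O)OCSc1ccccc1C(=O)NCCCNC(C)=O` has the same atoms as compound 2, joined differently: acetamido in place of carbamoylmethyl on a saturated chain carbon, three bonds along the chain from an amide-type nitrogen. Among the compounds with values here, no measured step rearranges a chain in this way; the one step known lengthens the chain and has a floor that lies within the scatter. Nothing here points to a change beyond the scatter, and for compound 3 the expected step is a 1.2-fold higher number from compound 2 to compound 3 (0.06 log units; within the scatter). The estimate for compound 3 is 60 uM, within a range from 25 uM to 120 uM.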

Compound 3, half-maximal toxic concentration: 21.1 uM
Beside the measured number, compound 3's estimate is 2.8-fold (0.45 log units) above it; the measured number lies below the stated range.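

In this assay, the same atoms joined differently already make a measurable difference: acetamido in place of carbamoylmethyl at this position gives a 2.5-fold lower number from compound 2 to compound 3 (0.39 log units; beyond the scatter) and no further comment on its size is needed beyond what it prints. For the compounds shown here, the earlier pair offered only a floor within the scatter, so this is the first step here that clearly passes it, showing that the arrangement of the chain counts and not just its atoms. The comparison with the first compound reads an at least 4.7-fold lower number from compound 1 to compound 3 (0.67 log units; beyond the scatter) but this is a floor and not a true size: the limit of > 100 uM in this assay, at which 1 of the 3 values shown sits.

The compounds shown leave open how an amine, a carboxylic acid or a longer chain ending in acetamido would read in this assay at this position. They also give no reason for the step, and a single pair cannot establish a pattern.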